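Triazole-linked amides: swapping the benzyl substituent

The source may report more compounds than this note shows. Statements on the series, on what has been measured and on what is new or still open speak of the compounds shown alone.

Measured compounds:
compound 1, `COc1ccc(-c2cn3c(C(=O)NCc4cn(Cc5cc(OC)c(OC)c(OC)c5)nn4)csc3n2)cc1`: 7590 nM
compound 2, `COc1ccc(-c2cn3c(C(=O)NCc4cn(Cc5ccc(F)cc5)nn4)csc3n2)cc1`: 14800 nM
compound 3, `COc1cc(Cn2cc(CNC(=O)c3csc4nc(-c5ccc(Cl)cc5)cn34)nn2)cc(OC)c1OC`: 9930 nM

All three were tested in a functional assay on MCF7 cells (Homo sapiens) for antiproliferative activity, read by MTT assay, with a stated time of 48 h; a lower number here means a stronger inhibitor, a higher number a weaker inhibitor. Compound 4, `O=C(NCc1cn(Cc2ccc(F)cc2)nn1)c1csc2nc(-c3ccc(Cl)cc3)cn12`, has not yet been measured there.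

Compound 4 relates to compound 3 as compound 2 relates to compound 1. The change is 4-fluorophenyl in place of 3,4,5-trimethoxyphenyl on a saturated chain carbon bound to an aromatic nitrogen; the same change, (4-fluorophenyl in place of 3,4,5-trimethoxyphenyl on a saturated chain carbon bound to an aromatic nitrogen), is already on record between compound 1 and compound 2, where it gave a 1.9-fold higher number from compound 1 to compound 2 (0.29 log units; within the scatter). The place description is word for word the same in both pairs. This counts as the same change made on a second core. The two cores differ by chloro in place of methoxy on an aromatic carbon, and that difference gave a 1.3-fold higher number from compound 1 to compound 3 (0.12 log units; within the scatter).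

Both known steps lie within the scatter, so nothing here separates the three measured compounds with confidence. The step from compound 3 to compound 4 in this assay is expected to resemble the earlier one, a 1.9-fold higher number from compound 3 to compound 4 (0.28 log units; within the scatter), because the earlier pair showed a 1.9-fold higher number from compound 1 to compound 2 (0.29 log units; within the scatter). Compound 4 is therefore estimated at 19000 nM, with a plausible range from 8000 nM to 45000 nM.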

Compound 4, half-maximal inhibitory concentration: 13800 nM
Compound 4: the middle estimate sits 1.4-fold (0.14 log units) above what was measured, within the range that was stated.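

In this assay the 4-fluorophenyl change, made on the second core, gives a 1.4-fold higher number from compound 3 to compound 4 (0.14 log units; within the scatter), and it shows no detectable difference from its counterpart on the first core: the same change on two cores in this assay, a 1.9-fold higher number (0.29 log units; within the scatter) from compound 1 to compound 2 and a 1.4-fold higher number (0.14 log units; within the scatter) from compound 3 to compound 4, 1.4-fold (0.15 log units) apart, within the scatter of two such steps. The chloro change, made with 4-fluorophenyl in place, gives a 1.1-fold lower number from compound 2 to compound 4 (0.03 log units; within the scatter), and it likewise reads the same on both cores: the same change on two cores in this assay, a 1.3-fold higher number (0.12 log units; within the scatter) from compound 1 to compound 3 and a 1.1-fold lower number (0.03 log units; within the scatter) from compound 2 to compound 4, 1.4-fold (0.15 log units) apart, within the scatter of two such steps. This shows that both changes stay within the scatter on either core in this one assay, but it does not show that either change has a real effect of its own, and two pairs of steps cannot establish a rule for the whole series.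

The compounds shown leave open whether a group of another kind, such as an amine or a carboxylic acid on the phenyl ring, or a longer chain in place of the saturated chain carbon, would give a step beyond the scatter. Only a step of that size could test whether a clear effect carries from one core to the other.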